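Replacing a selenium chain with benzylamino on the shared core

A few compounds are considered here, and "the series" means these few. Any claim that something is new, unique, unknown or untested is made for them only; others in the source may bear on it.

Compound 1: `CCCCC[Se]c1nc(N)c2ccccc2n1` — 34600 nM
Compound 2: `CSc1nc(NCCCCCO)c2ccccc2n1` — 31400 nM
Compound 3: `CCCCC[Se]c1nc([Se]CCCCC)c2ccccc2n1` — > 100000 nM

In a functional assay on HTB-54 cells (Homo sapiens) for cytotoxicity, read by MTT assay, with a stated time of 72 h (a higher number here means a weaker inhibitor of growth, a lower number a stronger inhibitor of growth), compound 3 reaches only the limit of the assay, > 100000 nM, and stands weakest of the three shown. Compound 4, `CCCCC[Se]c1nc(NCc2ccccc2)c2ccccc2n1`, differs from it by a group of 8 heavy atoms (7 carbon, 1 nitrogen; one six-membered aromatic ring of carbon only) in place of a group of 6 heavy atoms (5 carbon, 1 selenium; no ring), on an aromatic carbon. Going by the values given here, one measured step bears on this: an at least 2.8-fold higher number from compound 1 to compound 3 (0.46 log units; beyond the scatter), where a group of 6 heavy atoms replaced one nitrogen atom and the number rose, a step that rests on (the limit of > 100000 nM in this assay, at which 1 of the 3 values shown sits). Compound 4 reverses this in kind, bringing a nitrogen-bearing group back in, so the number is expected to fall rather than rise; the step of an at least 3.3-fold lower number from compound 3 to compound 4 (0.52 log units; beyond the scatter) is expected to bring compound 4 near compound 1 and compound 2. Compound 4 is estimated at 30000 nM, within 10000 nM to 100000 nM.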

Compound 4, concentration for 50% growth inhibition: 37700 nM
Beside the measured number, compound 4's estimate is 1.3-fold (0.10 log units) below it; the range from low to high includes it.
By their numbers in this assay, from the lowest: compounds 2, 1 and 4 (each within the scatter of the next). At a limit, above all of these: compound 3.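

In this assay, benzylamino in place of the selenium chain gives an at least 2.6-fold lower number from compound 3 to compound 4 (0.42 log units; beyond the scatter), and this step rests on a limit: the limit of > 100000 nM in this assay, at which 1 of the 4 values shown sits. With the free amino group as the comparison, benzyl on that nitrogen gives a 1.1-fold higher number from compound 1 to compound 4 (0.04 log units; within the scatter), so the benzyl group adds nothing that can be read beyond the scatter. At this position, then, both nitrogen-linked groups give a measured number, whereas the second selenium chain of compound 3 gives only a limit. On these data alone, whether an oxygen-linked chain here, or a benzyl ring bearing a carboxylic acid, would read like compound 4 stays open.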